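The source may report more compounds than this note shows. Statements on the series, on what has been measured and on what is new or still open speak of the compounds shown alone.

Measured compounds:
Compound 1 `COC(=O)N1N=C(c2cccc(OC)c2)CC1c1cc(OC)c(OC)c(OC)c1` gives 350 nM in a functional assay on MDA-MB-231 cells (Homo sapiens) for antiproliferative activity, read by MTT assay, with a stated time of 48 h; a lower number here means a stronger inhibitor of growth, a higher number a weaker inhibitor of growth.
Compound 2 `COc1cccc(C2=NN(C(=O)OCc3ccccc3)C(c3cc(OC)c(OC)c(OC)c3)C2)c1` gives > 10000 nM in this assay, which is a limit of the assay rather than a number.

Compound 1 therefore holds the only number shown in this assay; the one other value is a limit (the limit of > 10000 nM in this assay, at which 1 of the 2 values shown sits). Among the compounds with values here, the single measured step, an at least 28-fold higher number from compound 1 to compound 2 (1.45 log units; beyond the scatter), is large but touches a different part of the molecule: it changes the chain bound to the oxygen next to the carbonyl group, not the aromatic ring that carries the methoxy group. It shows that this series can lose activity sharply, but it gives no direction for a change on the ring.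

Compound 3 `COC(=O)N1N=C(c2cccc(C)c2)CC1c1cc(OC)c(OC)c(OC)c1` differs from compound 1 by methyl in place of methoxy on an aromatic carbon. Within the data shown here, no measured step bears on this aromatic carbon, so there is no basis for expecting a move beyond the scatter in either direction. The step expected from compound 1 to compound 3 is a 1.4-fold higher number from compound 1 to compound 3 (0.15 log units; within the scatter), and compound 3 is estimated at 500 nM in this assay, with a range from 150 nM to 2000 nM.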

Compound 3, concentration for 50% growth inhibition: 140 nM
For compound 3 the middle estimate is 3.6-fold (0.55 log units) above the measured one; measured number outside the range, below it.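

Within the data shown here, compound 3 gives the first measured reading at this aromatic carbon, and in this assay the change from 3-methoxyphenyl to 3-methylphenyl amounts to a 2.5-fold lower number from compound 1 to compound 3 (0.40 log units; beyond the scatter). The methoxy group is therefore not needed for activity at this position in this pair: methyl, with fewer heavy atoms and no hydrogen-bond acceptor, keeps growth inhibition and gives the lower number, a modest step beyond the scatter, so this aromatic carbon now has a measured direction that the earlier step on the chain bound to the oxygen could not supply. The data shown give no reason for this step, since the one limit among the values concerns a different part of the molecule.

Going by these compounds, with a single replacement at this carbon, it remains open whether the lower number is particular to methyl or would also appear with ethyl, chlorine, trifluoromethyl or an amine in the same place. On these data alone, it is equally open whether the methoxy-to-methyl step would carry over to other chains on the carbonyl group, such as ethyl or isopropyl, or whether it holds only with the shared core of compound 1.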